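Tolerance on HEp-2 cells after a trifluoro-hydroxy extension

The source may hold more compounds than are shown below. What is called first, only, known or untested is meant among the compounds shown, and "the series" means these compounds.

Compound 1 `CN(C)S(=O)(=O)c1cn(Cc2nc3cc(Cl)ccc3n2CCCS(C)(=O)=O)c2ccccc12`: > 100000 nM
Compound 2 `CS(=O)(=O)c1nn(Cc2nc3cc(Cl)ccc3n2CCO)c2cnccc12`: > 100000 nM

In an ADME assay on HEp-2 cells (Homo sapiens) for cytotoxicity, with a stated time of 4 days (a lower number here means that less compound is tolerated, a higher number that more compound is tolerated), compound 1 gives > 100000 nM, which is a limit of the assay rather than a number. In this assay compound 2 likewise gives > 100000 nM, also a limit. Among the measured compounds shown here, compound 2 thus stands only at the limit, and the one further value shown sits at the same place; both rest at the limit of > 100000 nM in this assay, at which 2 of the 2 values shown sit. Compound 3 `CS(=O)(=O)c1nn(Cc2nc3cc(Cl)ccc3n2CCC(O)C(F)(F)F)c2cnccc12` has not yet been measured in this assay. It differs from compound 2 in one place: 2,2,2-trifluoro-1-hydroxyethyl in place of hydroxy on a saturated chain carbon, two bonds along the chain from an aromatic nitrogen. For the measured compounds named here, no step between measured compounds is available to gauge this change. Both measured values are limits rather than numbers; they give no direction, and nothing here points to a change beyond the usual scatter. Compound 3 is therefore expected to give 100000 nM, within 30000 nM to 300000 nM. Expected is a step of a number no higher from compound 2 to compound 3 (the limit leaves the size open), none beyond the scatter.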

Compound 3, half-maximal cytotoxic concentration: > 100000 nM
Compound 3 gave a limit, no number; the forecaster's own chance of this, stated with the estimate: 70%; the middle value sits exactly at the limit.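

No step can be read from compound 2 to compound 3 in this assay because both give only a limit, not a number: the limit of > 100000 nM in this assay, at which 3 of the 3 values shown sit.

The compounds shown leave open where any of the three actually stands, and whether 2,2,2-trifluoro-1-hydroxyethyl in place of hydroxy changes tolerance at all.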